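The source may hold more compounds than are shown below. What is called first, only, known or untested is meant among the compounds shown, and "the series" means these compounds.

Measured so far:
- Compound 1, `COc1cc(-c2cc(/C=C/C(=O)c3ccc(N)cc3)[nH]n2)cc(OC)c1OC`: -95%
- Compound 2, `COc1cc(-c2cc(/C=C/C(=O)c3ccc(Cl)c(Cl)c3)[nH]n2)cc(OC)c1OC`: 62%
- Compound 3, `COc1ccc(C(=O)/C=C/c2cc(-c3cc(OC)c(OC)c(OC)c3)n[nH]2)cc1OC`: -98%

These three share one core and differ only in the aryl group attached to the carbonyl carbon. In a functional assay on SK-MEL-5 cells (Homo sapiens) for cytotoxicity, read by sulforhodamine B assay, with a stated time of 48 h, tested at 10 uM (a higher number here means a weaker effect of the compound at the concentration tested, a lower number a stronger effect), compound 3 gives the lowest of the three numbers, but its gap to compound 1 is small, a number 3 percentage points lower from compound 1 to compound 3 (within the scatter), so the two cannot be ranked against each other. The gap to compound 2 is a different matter: a number 160 percentage points lower from compound 2 to compound 3 (beyond the scatter).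

Compound 4, `COc1ccc(C(=O)/C=C/c2cc(-c3cc(OC)c(OC)c(OC)c3)n[nH]2)cc1`, has not yet been measured. It differs from compound 3 in one place: hydrogen in place of methoxy on an aromatic carbon.

For the measured compounds named here, no measured step removes a methoxy group from this ring, so none bears on the change directly. The steps that exist show only that swapping the whole aryl group can move the number a great deal, as in a number 160 percentage points lower from compound 2 to compound 3 (beyond the scatter), or hardly at all, as in a number 3 percentage points lower from compound 1 to compound 3 (within the scatter). Since compound 4 keeps one methoxy on the same ring, compound 4 is expected to stay near compound 3, with a step of about a number 13 percentage points higher from compound 3 to compound 4 (beyond the scatter) in this assay. The estimate for compound 4 is therefore -85%, within a range from -100% to -30%.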

Compound 4, a percentage reported as activity, at one concentration (the size of the read-out at that concentration, not a potency): -89%
Beside the measured number, compound 4's estimate is 4 percentage points above it; the measured number falls inside the stated range.
By their numbers in this assay, from the lowest: compounds 3, 1 and 4 (each within the scatter of the next); then compound 2.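

In this assay, the methoxy group on the 3,4-dimethoxyphenyl ring can go without a measurable loss, with a number 9 percentage points higher from compound 3 to compound 4 (within the scatter), so among these compounds the 4-methoxyphenyl group alone keeps the strong effect. That group also stays far from the 3,4-dichlorophenyl group, with a number 151 percentage points lower from compound 2 to compound 4 (beyond the scatter), and cannot be told apart from the amino compound, with a number 6 percentage points higher from compound 1 to compound 4 (within the scatter). Nothing available here explains why these aryl groups give such different numbers.

The compounds shown leave open what happens when the remaining methoxy gives way to hydrogen, a hydroxyl or an ethoxy group. They also leave open whether a ring with a single chlorine would read like the 3,4-dichlorophenyl compound or like the 4-methoxyphenyl one.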